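Chloro in place of methyl on compound 1

A few compounds are considered here, and "the series" means these few. Any claim that something is new, unique, unknown or untested is made for them only; others in the source may bear on it.

In a functional assay on HUVEC cells (Homo sapiens), read by BrdU incorporation, with a stated time of 72 h (a higher number here means a weaker inhibitor, a lower number a stronger inhibitor), compound 1 `Cc1ccc2nc(Cl)c(/C=C/C(=O)c3sccc3C)cc2c1` gives 127 nM, compound 2 `Cc1ccc2cc(/C=C/C(=O)c3ccc(I)s3)c(Cl)nc2c1` gives 135 nM and compound 3 `Cc1ccc2cc(/C=C/C(=O)c3ccc(Br)s3)c(Cl)nc2c1` gives 83.6 nM. These three numbers lie within the scatter of one another, so compound 1 holds no distinct place among them.

Compound 4 `Cc1ccc2nc(Cl)c(/C=C/C(=O)c3sccc3Cl)cc2c1` is still to be measured. Its change from compound 1 is chloro in place of methyl on an aromatic carbon, on an aromatic carbon of a five-membered aromatic ring with 1 sulfur, next to the ring atom that bears a large group. The same difference reads 3-methylthiophen-2-yl to 3-chlorothiophen-2-yl.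

Among the measured compounds shown here, only one measured step is available as a guide: a 1.6-fold lower number from compound 2 to compound 3 (0.21 log units; within the scatter), with bromo in place of iodo on an aromatic carbon. That step stays within the scatter, but it bears on the new change only loosely. For the measured compounds named here, no measured step has methyl leaving or chloro entering, and compound 1 has no measured step of its own.

On these data alone, with so little to go on, no shift beyond the scatter is expected in this assay, and the direction remains open. The expected step is a 1.2-fold lower number from compound 1 to compound 4 (0.06 log units; within the scatter). For compound 4 the estimated value is 110 nM, with an expected range of 50 nM to 250 nM.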

Compound 4, half-maximal inhibitory concentration: 37.5 nM
Compound 4: the middle estimate sits 2.9-fold (0.47 log units) above what was measured; measured number outside the range, below it.
By their numbers in this assay, from the lowest: compound 4; then compounds 3, 1 and 2 (each within the scatter of the next).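

In this assay, among the compounds shown here, chloro in place of methyl gives a 3.4-fold lower number from compound 1 to compound 4 (0.53 log units; beyond the scatter) and is the only step so far that lies beyond the scatter. For the compounds shown here, this shows that the number responds to the exchange of a single heavy atom on an aromatic carbon of a five-membered aromatic ring with 1 sulfur, next to the ring atom that bears a large group, in the change from 3-methylthiophen-2-yl to 3-chlorothiophen-2-yl, whereas the only earlier step, a 1.6-fold lower number from compound 2 to compound 3 (0.21 log units; within the scatter) for bromo in place of iodo, stayed within the scatter and gave no sign of such a response. No evidence on hand gives a cause for this step.

On these data alone, whether fluoro, bromo, methoxy, a nitrile or an amine at this same place would give a number near that of the chloro compound or near that of the methyl compound remains open. As far as these compounds go, it also remains open whether the step would carry over to other substituents on the shared core, as it rests on a single pair of compounds.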